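From 4-chlorophenyl to 2-chlorophenyl on compound 1

This account rests on a few compounds, and the source may have more. Where it says the series, first, only, none or still open, it means among the compounds named here.

Of the compounds shown here, three have so far been measured in a physicochemical assay for lipophilicity (on this read-out lower numbers stand for lower lipophilicity and higher numbers for higher lipophilicity), and their numbers are spread over a modest range. Compound 1 (`CNC(=O)c1cc(C(=O)N[C@H]2CC[C@H](O)CC2)n([C@@H](C)c2ccc(Cl)cc2)n1`) reads 3.7 and holds the highest number of the three. Compound 3 (`CNC(=O)c1cc(C(=O)NC)n([C@@H](C)c2ccccc2)n1`) reads 3 and compound 2 (`CNC(=O)c1cc(C(=O)NC2CC2)cn(Cc2cccc3[nH]ccc23)c1=O`) reads 2.9 and each of these lies lower than compound 1 by more than the usual scatter.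

Compound 4 (`CNC(=O)c1cc(C(=O)N[C@H]2CC[C@H](O)CC2)n([C@@H](C)c2ccccc2Cl)n1`) has not yet been measured. It contains the same atoms as compound 1 but joined differently (2-chlorophenyl in place of 4-chlorophenyl on a saturated chain carbon bound to an aromatic nitrogen and a saturated chain carbon). The swap takes place on a saturated chain carbon bound to an aromatic nitrogen and a saturated chain carbon, and the rest of the structure stays as it is.

For the measured compounds named here, no two measured compounds differ in one place only, so the data offer no direct precedent for this change. The expectation therefore starts from compound 1 at 3.7 and allows only a small shift for a chlorophenyl group exchanged for a chlorophenyl group. The expected step is slightly downward and stays within the scatter (a number 0.10 log units lower from compound 1 to compound 4 (within the scatter)). In this assay compound 4 is estimated at 3.6 with an expected range from 3.2 to 3.9 for the coming measurement.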

Compound 4, distribution coefficient: 3.9
Estimate against measurement, compound 4: 0.30 log units below; the measured number falls inside the stated range.
By their numbers in this assay, from the lowest: compounds 2 and 3 (each within the scatter of the next); then compounds 1 and 4 (each within the scatter of the next).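

For the compounds shown here, the exchange of 4-chlorophenyl for 2-chlorophenyl, on a saturated chain carbon bound to an aromatic nitrogen and a saturated chain carbon, is the first change in this set that can be read in one place, and in this assay it gives a number 0.20 log units higher from compound 1 to compound 4 (within the scatter) with the rest of the structure held constant. At this position, then, the read-out does not separate the two chlorophenyl groups, and for this pair the place of the chlorine on the aromatic ring makes no difference that can be told from the usual scatter. The data offer nothing that would explain this result.

On these data alone, whether 3-chlorophenyl, or a fluorine or a methoxy group in place of the chlorine, would also stay within the scatter of compound 1 in this assay remains open. The compounds shown also leave open how an amine or a carboxylic acid would read at this position, and whether the same exchange would give a step of similar size on a different core.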